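The compounds below may be only part of what the source reports. "The series", "measured", "known", "first", "only" and "open" are said of these compounds alone.

Compound 1 `CC1=CC[C@H]2[C@H](CC[C@]2(C)O)C(C)(C)[C@@H]1CC[C@H]1[C@]2(C)CC[C@H](OC(=O)c3ccc(C)cc3)C(C)(C)O[C@H]2CC[C@@]1(C)O`: > 50000 nM
Compound 2 `CC1=CC[C@H]2[C@@H]1CC=C(C)[C@@H](CC[C@H]1[C@]3(C)CC[C@H](OC(=O)c4ccc(C)cc4)C(C)(C)O[C@H]3CC[C@@]1(C)O)C2(C)C`: > 50000 nM

In a functional assay on MCF7 cells (Homo sapiens) for antiproliferative activity, read by MTT assay, with a stated time of 72 h (on this read-out higher numbers stand for weaker inhibition and lower numbers for stronger inhibition), compound 1 gives only a limit, > 50000 nM. Compound 2 likewise yields only a limit in this assay, > 50000 nM. Both measured values thus sit at the limit of > 50000 nM in this assay, at which 2 of the 2 values shown sit, and compound 1 stands at that limit with no number of its own. Compound 3 `CC1=CC[C@H]2[C@H](CC[C@]2(C)O)C(C)(C)[C@@H]1CC[C@H]1[C@]2(C)CC[C@H](OC(=O)c3ccccc3F)C(C)(C)O[C@H]2CC[C@@]1(C)O` has not yet been measured and differs from compound 1 in one place: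
2-fluorophenyl in place of 4-methylphenyl on a carbonyl carbon
Among the compounds with values here, no measured step exists to guide this change, so the step expected from compound 1 to compound 3, a number no higher from compound 1 to compound 3 (the limit leaves the size open), is none beyond the scatter. Compound 3 is therefore estimated at 50000 nM, between 20000 nM and 100000 nM, most likely again reported only as a limit.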

Compound 3, half-maximal inhibitory concentration: 11300 nM
Compound 3: middle estimate off by 4.4-fold (0.65 log units), on the high side; the measured number lies below the stated range.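

Replacing 4-methylphenyl with 2-fluorophenyl on the carbonyl carbon gives an at least 4.4-fold lower number from compound 1 to compound 3 (0.64 log units; beyond the scatter) in this assay. Within the data shown here, this shows that the group at this place can move the read-out, which the earlier compounds, both held at a limit, could not show. The true size of the step stays unknown, since compound 1 gives only a limit: the limit of > 50000 nM in this assay, at which 2 of the 3 values shown sit.

From the compounds shown here alone, whether the fluorine or the loss of the methyl matters more stays open, as does the effect of a plain phenyl, a pyridine ring or an amine here. Also open, going by these compounds, is whether the same change would act alike on the core of compound 2.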